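The source may hold more compounds than are shown below. What is called first, only, known or untested is meant among the compounds shown, and "the series" means these compounds.

Measured compounds:
compound 1 `CC1CCN(c2c(S(=O)(=O)c3cc(Cl)cc(Cl)c3)cnc3ccc(Cl)cc23)CC1`, this assay: 88%
compound 2 `CC1CCN(c2c(S(=O)(=O)c3ccc(F)c(F)c3)cnc3ccc(Cl)cc23)CC1`, this assay: 72%

Among the measured compounds shown here, in an assay on isolated protein for displacement of a labelled ligand from metabotropic glutamate receptor 5 (Homo sapiens), with a stated time of 60 min, tested at 1 uM (a higher number here means more inhibition at the concentration tested (going by the name of the read-out), a lower number less inhibition), compound 2 gives the lower of the two numbers; compound 1 stands above it, and the step of a number 16 percentage points lower from compound 1 to compound 2 (beyond the scatter) is the only measured change at the sulfonyl sulfur. Compound 3 `Cc1ccc(S(=O)(=O)c2cnc3ccc(Cl)cc3c2N2CCC(C)CC2)cc1Cl` differs from compound 2 by 3-chloro-4-methylphenyl in place of 3,4-difluorophenyl on a sulfonyl sulfur. Since the step from 3,5-dichlorophenyl to 3,4-difluorophenyl lowered the read-out, and the entering group carries one chlorine, a modest rise back toward compound 1 is expected. Compound 3 is therefore estimated at 82%, in the range 68% to 93%, a step of a number 10 percentage points higher from compound 2 to compound 3 (within the scatter).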

Compound 3, a percentage reported as inhibition, at one concentration (the size of the read-out at that concentration, not a potency): 81%
Estimate against measurement, compound 3: 1 percentage points above, and the stated range covers the measured number.
By their numbers in this assay, from the lowest: compounds 2, 3 and 1 (each within the scatter of the next, the first and the last beyond it).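

In this assay the 3-chloro-4-methylphenyl group of compound 3 cannot be told apart from either of the other aryl groups on the sulfonyl sulfur: the reading shows a number 9 percentage points higher from compound 2 to compound 3 (within the scatter) and also a number 7 percentage points lower from compound 1 to compound 3 (within the scatter) and both steps lie within the scatter. The clear gap between compound 1 and compound 2 therefore remains the only one resolved at this position. Nothing available bears on the reason for these numbers.

From the compounds shown here alone, whether an amine or a carboxylic acid on the aryl ring would keep the read-out stays open. So does the effect of replacing the aryl ring on the sulfonyl sulfur with a saturated group such as cyclohexyl.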